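A few compounds are considered here, and "the series" means these few. Any claim that something is new, unique, unknown or untested is made for them only; others in the source may bear on it.

Compound 1 `CCCCCCCCCCCCCCCCCC(=O)CCCCOP(=O)(O)OC[C@H](N)C(=O)O` belongs to this small set, but in a functional assay on cells (Mast cell, Mus musculus, strain C57BL/6) for activation, read by fluorescence, with a stated time of 15 min (a higher number here means that more compound is needed for the effect, a lower number that less compound is needed), compound 1 has the outcome "not determined" (no result reported), so it gives no point of reference. Among the measured compounds shown here, compound 2 `CCCCCCCCCCCCCCCCCC(=O)OCCCOP(=O)(O)O[C@H](C)[C@H](N)C(=O)O` is the only member with a number: in this assay compound 2 gives 7 nM, a strong effect at a small amount of compound. For the measured compounds named here, compound 3 `CCCCCCCCCCCCCCCC(=O)OCCCOP(=O)(O)O[C@H](C)[C@H](N)C(=O)O` stands without a number, since in this assay compound 3 shows "not determined" (no result reported); its place on the scale is therefore open, and the single measured value of compound 2 is all that anchors this family.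

Compound 4 `CCCCCCCCCCCCCCCC(=O)OC[C@@H](O)COP(=O)(O)O[C@H](C)[C@H](N)C(=O)O` is reached from compound 3 by one change: hydroxy in place of hydrogen on a saturated chain carbon bound to two saturated chain carbons. Going by the values given here, with no step between two measured compounds available, only a cautious expectation is possible. The change is small in size and touches the linker rather than the acid or the amino acid end, so in this assay a step of no more than the usual scatter is expected, in either direction. On that basis compound 4 is expected to give about 10 nM, estimated between 2 nM and 60 nM.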

Compound 4, half-maximal effective concentration: 20 nM
Estimate against measurement, compound 4: 2.0-fold (0.30 log units) below; the range from low to high includes it.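

No new step can be read here, since compound 3 has no single number in this assay to set against compound 4. Going by these compounds, what the hydroxy in place of hydrogen does to the effect stays open. No other evidence bears on this result.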